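The source may report more compounds than this note shows. Statements on the series, on what has been measured and on what is new or still open speak of the compounds shown alone.

Working notes on the series. Three compounds have been run so far. Compound 1 `CN1CCN(CC#CCn2ccnc2)C1=O` and compound 2 `CN(C)CC#CCN1CCN(C)C1=O` share one core, while compound 3 `Cn1ccn(CC#CCn2ccnc2)c1=O` is built on a second core; the difference between the two cores is not broken down here. In a functional assay on the whole organism for agonist activity, with Mus musculus as the target (a higher number here means that more compound is needed for the effect, a lower number that less compound is needed), compound 1 gives 1.4 mg/kg. In the same assay compound 2 gives 0.54 mg/kg. Compound 3 gives 3.7 mg/kg, the highest number of the three, with compound 1 nearest to it and compound 2 furthest from it.

For the measured compounds named here, the single counted change within the measured set is dimethylamino in place of 1H-imidazol-1-yl on a saturated chain carbon bound to a triple-bonded carbon. Across that change the reading moves as a 2.6-fold lower number from compound 1 to compound 2 (0.41 log units; beyond the scatter), a step beyond the usual scatter.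

Compound 4 `CN(C)CC#CCn1ccn(C)c1=O` has not yet been measured. It stands to compound 3 exactly as compound 2 stands to compound 1: dimethylamino in place of 1H-imidazol-1-yl on a saturated chain carbon bound to a triple-bonded carbon. The place of the change reads the same word for word in both pairs, so this is the same change, made twice in all among the compounds shown, once with a measured outcome and once still open.

If the change carries over from one core to the other, the step from compound 3 to compound 4 is expected to be a 2.6-fold lower number from compound 3 to compound 4 (0.42 log units; beyond the scatter), resting on the measured 2.6-fold lower number from compound 1 to compound 2 (0.41 log units; beyond the scatter). Going by the values given here, only one measured instance exists and the cores differ, so the expectation is held loosely. For compound 4 in this assay the estimate is 1.4 mg/kg, expected to fall between 0.7 mg/kg and 3 mg/kg.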

Compound 4, dose for half-maximal effect: 8 mg/kg
Compound 4: the middle estimate sits 5.7-fold (0.76 log units) below what was measured, and the stated range ends below it.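

In this assay the replacement of 1H-imidazol-1-yl by dimethylamino on a saturated chain carbon bound to a triple-bonded carbon does not carry over from the core of compound 1 to the core of compound 3, since it gives a 2.2-fold higher number from compound 3 to compound 4 (0.33 log units; beyond the scatter), a step in the opposite direction to the earlier one. The two steps are set side by side here, and the gap between them is larger than chance scatter would account for: the same change on two cores in this assay, a 2.6-fold lower number (0.41 log units; beyond the scatter) from compound 1 to compound 2 and a 2.2-fold higher number (0.33 log units; beyond the scatter) from compound 3 to compound 4, 5.6-fold (0.75 log units) apart, beyond the scatter of two such steps This shows that, within these two pairs, the direction of the change depends on the core it is made on, so a measured step on one core is no safe guide to the other; it does not show which feature of the cores is responsible, and with a single pair on each core it gives no general rule for the series.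

From the compounds shown here alone, it remains open whether another amine in the same place, such as diethylamino, would also split in direction between the two cores. For the compounds shown here, it is equally open whether a longer chain in place of the one carrying these groups would keep the same split.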